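The source may report more compounds than this note shows. Statements on the series, on what has been measured and on what is new or still open speak of the compounds shown alone.

Measured compounds in a functional assay on HT cells (Homo sapiens) for antiproliferative activity, read by fluorescence, with a stated time of 72 h; a lower number here means a stronger inhibitor of growth, a higher number a weaker inhibitor of growth:
compound 1, `CC(C)c1n[nH]c2c(NCc3ccc(-c4ccccn4)cc3)nc(SCC(O)CN3CCNCC3)nc12`, gives 332 nM
compound 2, `CC(C)c1n[nH]c2c(NCc3ccc(-c4ccccn4)cc3)nc(SCC(C)(C)O)nc12`, gives 507 nM
compound 3, `CSc1nc(NCc2ccc(-c3ccccn3)cc2)c2[nH]nc(C(C)C)c2n1`, gives 783 nM

Compound 3 carries the highest number of the three. Its nearest neighbour is compound 2, and the step of a 1.5-fold higher number from compound 2 to compound 3 (0.19 log units; within the scatter) lies within the scatter, so the two cannot be ordered. The step of a 2.4-fold higher number from compound 1 to compound 3 (0.37 log units; beyond the scatter) is beyond the scatter, so compound 1 does stand apart from compound 3 as the stronger inhibitor of growth. The step of a 1.5-fold higher number from compound 1 to compound 2 (0.18 log units; within the scatter) is within the scatter.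

Compound 4, `CC(C)c1n[nH]c2c(NCc3ccc(-c4ccccn4)cc3)nc(SCCC(N)=O)nc12`, is not yet measured. It differs from compound 3 as follows: carbamoylmethyl in place of hydrogen on a saturated chain carbon bound to a sulfur. The relevant measured steps are those that also alter the saturated chain carbon bound to a sulfur: a 1.5-fold higher number from compound 2 to compound 3 (0.19 log units; within the scatter), within the scatter, and a 2.4-fold higher number from compound 1 to compound 3 (0.37 log units; beyond the scatter), modest and beyond the scatter. Both run toward lower numbers when the hydrogen is replaced. The carbamoylmethyl group is closer in size to the 1-hydroxy-1-methylethyl group of compound 2 than to the larger group of compound 1. A small move toward a lower number is therefore expected, possibly staying within the scatter, which the estimated step of a 1.6-fold lower number from compound 3 to compound 4 (0.21 log units; within the scatter) reflects. Compound 4 is estimated at 480 nM, with a range from 200 nM to 1100 nM.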

Compound 4, concentration for 50% growth inhibition: 120 nM
For compound 4 the middle estimate is 4.0-fold (0.60 log units) above the measured one; the whole stated range lies above it.
By their numbers in this assay, from the lowest: compound 4; then compounds 1, 2 and 3 (each within the scatter of the next, the first and the last beyond it).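

Working notes on the saturated chain carbon bound to a sulfur, in this assay: carbamoylmethyl is the first group at this place to set a compound clearly apart from all the others, with a 6.5-fold lower number from compound 3 to compound 4 (0.81 log units; beyond the scatter) and with a 4.2-fold lower number from compound 2 to compound 4 (0.63 log units; beyond the scatter) and also with a 2.8-fold lower number from compound 1 to compound 4 (0.44 log units; beyond the scatter) as the three steps that do so. Among the compounds shown, the number does not follow the size of the group, since the ring-free carbamoylmethyl gives a lower number than both 1-hydroxy-1-methylethyl and the larger 1-hydroxy-2-(piperazin-1-yl)ethyl, which carries a piperazine ring. No measurement at hand accounts for the gain at this position.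

The compounds shown do not separate the contribution of the terminal carbamoyl group from that of the chain carrying it. A carboxylic acid or a primary amine on the same chain, and a longer chain ending in the same carbamoyl group, would show which of the two the lower number follows.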